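The source may hold more compounds than are shown below. What is called first, only, known or untested is meant among the compounds shown, and "the series" means these compounds.

Measured in a functional assay on A-375 cells (Homo sapiens) for antiproliferative activity, read by CCK-8 assay, with a stated time of 72 h, tested at 8 uM; on this read-out lower numbers stand for a weaker effect and higher numbers for a stronger effect at the one concentration tested:
compound 1 `Nc1ccccc1NC(=O)c1ccc(CSC(=S)N2CCN(Cc3ccccn3)CC2)cc1` gives 82.4%
compound 2 `CC1CCN(C(=S)SCc2ccc(C(=O)Nc3ccccc3N)cc2)CC1` gives 87.4%
compound 3 `CN(Cc1cccnc1)C(=S)SCc1ccc(C(=O)Nc2ccccc2N)cc1` gives 83.8%

Compound 1 holds the lowest of the three numbers, but its gaps to compound 3 and to compound 2 both lie within the scatter, so the three read as level. Compound 4 `Nc1ccccc1NC(=O)c1ccc(CSC(=S)N2CCN(c3ccccc3F)CC2)cc1` differs from compound 1 by 2-fluorophenyl in place of (pyridin-2-yl)methyl on an amine nitrogen in a ring. Within the data shown here, the only measured step, a number 3.6 percentage points lower from compound 2 to compound 3 (within the scatter), exchanges the group on the thiocarbonyl carbon rather than the group on the ring nitrogen, so it bears only loosely on this change; it was itself within the scatter, and nothing measured here separates the compounds. No step beyond the scatter is therefore expected in this assay: compound 4 is estimated at 83%, range 72% to 92%, an expected a number 0.6 percentage points higher from compound 1 to compound 4 (within the scatter).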

Compound 4, a percentage reported as inhibition, at one concentration (the size of the read-out at that concentration, not a potency): 79.5%
Compound 4: middle estimate off by 3.5 percentage points, on the high side; measured number inside the range.
By their numbers in this assay, from the lowest: compounds 4, 1, 3 and 2 (each within the scatter of the next).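

In this assay, 2-fluorophenyl in place of (pyridin-2-yl)methyl on the amine nitrogen in the ring gives the first step read at this position (a number 2.9 percentage points lower from compound 1 to compound 4 (within the scatter)). The exchange takes out the ring nitrogen and the hydrogen-bond acceptor of the leaving group, and the number does not move beyond the scatter. No supporting measurement bears on this step, so it stays without an explanation.

The step changes the ring and its link together, so their separate contributions remain unresolved. A plain phenyl or benzyl group on this nitrogen would separate them, while a carboxylic acid would test a different kind of group.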